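Swapping the Amino Group: From Compound 2 to Compound 3

The source may hold more compounds than are shown below. What is called first, only, known or untested is meant among the compounds shown, and "the series" means these compounds.

Compound 1 `Cc1cc(NC(C)C)nc(SCc2nc3ccccc3[nH]2)n1`: this assay > 100000 nM
Compound 2 `Cc1cc(N(C)Cc2ccccc2)nc(SCc2nc3ccccc3[nH]2)n1`: this assay 31300 nM

Within the data shown here, compound 2 is the only compound here with a number: in a functional assay on MGC-803 cells (Homo sapiens) for cytotoxicity, read by MTT assay, with a stated time of 72 h (on this read-out lower numbers stand for stronger inhibition and higher numbers for weaker inhibition), compound 2 gives 31300 nM. Compound 1 sits at a limit of the assay, > 100000 nM, which is the limit of > 100000 nM in this assay, at which 1 of the 2 values shown sits. Compound 3 `Cc1cc(Nc2ccc(F)cc2)nc(SCc2nc3ccccc3[nH]2)n1` is not yet measured. It differs from compound 2 in one place: (4-fluorophenyl)amino in place of benzyl(methyl)amino on an aromatic carbon. Among the measured compounds shown here, the single measured step touches the same amino group: an at least 3.1-fold lower number from compound 1 to compound 2 (0.50 log units; beyond the scatter). That step starts from a limit, so its true size is open. Compound 3 keeps an aromatic ring on the amine, as compound 2 does, so only a change of modest size in this assay is expected, a 1.6-fold lower number from compound 2 to compound 3 (0.19 log units; within the scatter), with the direction uncertain. Compound 3 is therefore expected to give 20000 nM, within a range of 5000 nM to 80000 nM.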

Compound 3, half-maximal inhibitory concentration: 5770 nM
Compound 3: middle estimate off by 3.5-fold (0.54 log units), on the high side, and the stated range covers the measured number.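

In this assay, the amino position on the shared core responds to more than the presence of an aromatic ring: (4-fluorophenyl)amino in place of benzyl(methyl)amino gives a 5.4-fold lower number from compound 2 to compound 3 (0.73 log units; beyond the scatter), and unlike the earlier step, this one has a number at both ends. With 4-fluorophenyl in place of isopropyl on the same nitrogen, the series shows an at least 17-fold lower number from compound 1 to compound 3 (1.23 log units; beyond the scatter). From the compounds shown here alone, the true size of that step stays open because compound 1 stands at a limit: the limit of > 100000 nM in this assay, at which 1 of the 3 values shown sits.

The compounds shown leave open which part of the change matters, since the fluorine, the amine hydrogen and the link from ring to nitrogen all differ together in the step to compound 3. Phenylamino, (4-chlorophenyl)amino or (4-methoxyphenyl)amino at this position would help separate these features.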